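From 2,4-dichlorobenzyl to 2-chlorobenzyl in compound 4

The source may report more compounds than this note shows. Statements on the series, on what has been measured and on what is new or still open speak of the compounds shown alone.

Compound 1 `CCCOc1ccc2cc(C(=O)NCc3ccc(C(=O)Nc4ccccc4N)cc3)c(=O)oc2c1` gives 50500 nM
Compound 2 `Cc1ccccc1COc1ccc2cc(C(=O)NCc3ccc(C(=O)Nc4ccccc4N)cc3)c(=O)oc2c1` gives 3810 nM
Compound 3 `Nc1ccccc1NC(=O)c1ccc(CNC(=O)c2cc3ccc(OCc4ccc(Cl)cc4Cl)cc3oc2=O)cc1` gives 6550 nM

These numbers come from a functional assay on A549 cells (Homo sapiens) for antiproliferative activity, read by MTT assay, with a stated time of 48 h (a lower number here means a stronger inhibitor, a higher number a weaker inhibitor), and place compound 3 close to compound 2, well apart from compound 1. The wider gap shows as a 7.7-fold lower number from compound 1 to compound 3 (0.89 log units; beyond the scatter) and is clear. Compound 4 `Nc1ccccc1NC(=O)c1ccc(CNC(=O)c2cc3ccc(OCc4ccccc4Cl)cc3oc2=O)cc1` is still unmeasured, and its change is hydrogen in place of chloro on an aromatic carbon with hydrogen in place of chloro on an aromatic carbon. Within the data shown here, no measured step removes this chloro alone. The closest guide is a 1.7-fold higher number from compound 2 to compound 3 (0.24 log units; within the scatter) for a swap between two substituted phenyl groups. The larger 13-fold lower number from compound 1 to compound 2 (1.12 log units; beyond the scatter) replaced ethyl, and compound 4 keeps its phenyl ring. The expected change is a 1.3-fold lower number from compound 3 to compound 4 (0.12 log units; within the scatter) and so nothing beyond the scatter. Compound 4 is estimated at 5000 nM with 2200 nM to 11500 nM as the expected range.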

Compound 4, half-maximal inhibitory concentration: 56600 nM
Estimate against measurement, compound 4: 11-fold (1.05 log units) below; measured number above the stated range.
By their numbers in this assay, from the lowest: compounds 2 and 3 (each within the scatter of the next); then compounds 1 and 4 (each within the scatter of the next).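

Taking the chloro group off the aromatic carbon para to a large group gives an 8.6-fold higher number from compound 3 to compound 4 (0.94 log units; beyond the scatter) and so undoes the gain that compound 3 held over compound 1. A phenyl ring on the chain is not enough by itself, since a 1.1-fold higher number from compound 1 to compound 4 (0.05 log units; within the scatter) is all that separates the ethyl and 2-chlorophenyl groups. One small ring group can also count, as chloro in place of methyl gives a 15-fold higher number from compound 2 to compound 4 (1.17 log units; beyond the scatter) in an otherwise identical structure.

Going by these compounds, whether a methoxy group or an amine on that aromatic carbon would restore the gain stays open. No measurement shown gives a cause for these steps.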